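The compounds below may be only part of what the source reports. "The series", "measured", "known", "first", "only" and "open" are said of these compounds alone.

In an ADME assay on Caco-2 cells (Homo sapiens) for permeability, in the apical to basolateral direction (a higher number here means that the compound crosses the layer faster, a lower number that the compound crosses the layer more slowly), compound 1 `Cn1cc(-c2ccc(C(F)(F)F)cc2)c2cc(F)c(C(=O)NS(=O)(=O)C3CC3)cc21` gives 46 nm/s. Among the measured compounds shown here, this is the only number available, as the entry for compound 2 `Cn1cc(-c2ccc(C(F)(F)F)cc2)c2ccc(C(=O)NS(=O)(=O)C3CC3)cc21` reads "not determined" (no result reported). Compound 1 therefore cannot be ranked against any other compound. Compound 3 `Cn1cc(-c2ccc(C(F)F)cc2)c2cc(F)c(C(=O)NS(=O)(=O)C3CC3)cc21` differs from compound 1 in a single place: hydrogen in place of fluoro on a saturated chain carbon bound to an aromatic carbon and two fluorine atoms. In words, this is hydrogen in place of fluoro on a saturated chain carbon bound to an aromatic carbon and two fluorine atoms, so that 4-(trifluoromethyl)phenyl becomes 4-(difluoromethyl)phenyl. For the measured compounds named here, no measured pair shows what this change does in this assay, and so no shift beyond the usual scatter is expected. The estimated step, a 1.1-fold lower number from compound 1 to compound 3 (0.04 log units; within the scatter), is accordingly small and carries no firm direction. For compound 3 the expected value is 42 nm/s, with an estimated range of 18 nm/s to 95 nm/s.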

Compound 3, apparent permeability: 81 nm/s
Compound 3: the middle estimate sits 1.9-fold (0.29 log units) below what was measured; low and high end bracket the measured number.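

Replacing fluoro with hydrogen on the saturated chain carbon, so that 4-(trifluoromethyl)phenyl becomes 4-(difluoromethyl)phenyl, gives a 1.8-fold higher number from compound 1 to compound 3 (0.25 log units; within the scatter) in this assay. Among the compounds shown here, this is the first measured pair, and it shows that this single change leaves the two compounds within the scatter of each other, so no direction can be assigned to it. Nothing available explains the reading of this pair.

The compounds shown leave open what a larger change at this place would do in this assay, such as a methoxy group, a nitrile or a plain methyl group in place of the trifluoromethyl. They also leave open whether the same replacement would read alike on a different core.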